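The compounds below may be only part of what the source reports. "The series", "measured", "known", "first", "only" and "open" are said of these compounds alone.

Working notes on the naphthalene-free description: the series shares one core, carried unchanged by compound 1 `COc1ccc(S(=O)(=O)N(CC(N)=O)c2ccc(N(CC(N)=O)S(=O)(=O)c3ccc(NC(C)=O)cc3)c3ccccc23)cc1`, compound 2 `COc1ccc(S(=O)(=O)N(CC(N)=O)c2ccc(N(CC(N)=O)S(=O)(=O)c3ccc(NC(=O)CN4CCC(C)CC4)cc3)c3ccccc23)cc1` and compound 3 `CCN1CCN(CCCC(=O)Nc2ccc(S(=O)(=O)N(CC(N)=O)c3ccc(N(CC(N)=O)S(=O)(=O)c4ccc(OC)cc4)c4ccccc34)cc2)CC1`, which differ only in the group on the saturated chain carbon bound to the carbonyl carbon of the anilide. In a functional assay on cells (Peritoneal macrophage, Mus musculus) for cytotoxicity, with a stated time of 24 h (a higher number here means that more compound is tolerated, a lower number that less compound is tolerated), compound 1 gives > 50000 nM, a limit of the assay. In this assay compound 2 gives > 50000 nM, again a limit. In this assay compound 3 gives > 100000 nM, also a limit. The three steps among them, a step that the two limits leave unreadable from compound 1 to compound 2, a step that the two limits leave unreadable from compound 1 to compound 3 and a step that the two limits leave unreadable from compound 2 to compound 3, are therefore all unreadable; what remains is the limit of > 50000 nM in this assay, at which 2 of the 3 values shown sit, and (the limit of > 100000 nM in this assay, at which 1 of the 3 values shown sits). Compound 4 `COc1ccc(S(=O)(=O)N(CC(N)=O)c2ccc(N(CC(N)=O)S(=O)(=O)c3ccc(NC(=O)CCCN4CCN(C(C)C)CC4)cc3)c3ccccc23)cc1` is the next member, differing from compound 2 as 2-(4-isopropylpiperazin-1-yl)ethyl in place of 4-methylpiperidin-1-yl on a saturated chain carbon bound to a carbonyl carbon. Among the compounds with values here, the step that bears most closely on it is the one from compound 2 to compound 3, since both exchange the 4-methylpiperidin-1-yl for a piperazine-bearing chain, and that step gave no readable size. No step beyond the scatter is expected for a step that the limit leaves unreadable from compound 2 to compound 4, and a limit rather than a number is the likely outcome. Compound 4 is accordingly expected to sit around 70000 nM, with a range from 30000 nM to 200000 nM.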

Compound 4, half-maximal cytotoxic concentration: > 100000 nM
Compound 4: a limit, no number; the forecaster's own chance of this, stated with the estimate: 80%; middle value at least 1.4-fold (0.15 log units) from the limit.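

In this assay compound 4 gives > 100000 nM, a limit and not a number. Within the data shown here, no step from compound 1, compound 2 or compound 3 to compound 4 can be read. The compounds shown leave open where the half-maximal cytotoxic concentration of any of the four lies, and whether the group exchanged on the chain alters it.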